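The compounds below may be only part of what the source reports. "The series", "measured", "known", "first", "only" and "open" are said of these compounds alone.

Three related compounds have numbers in an ADME assay on J774.A1 cells (Mus musculus) for cytotoxicity, read by MTT assay, with a stated time of 72 h; on this read-out higher numbers stand for lower toxicity in this test and lower numbers for higher toxicity in this test. Compound 1 (`CC1(c2ccc(-c3ccccc3C#N)cc2)CC(S(=O)(=O)c2ccc(F)cc2)=C(c2ccc(/C(N)=N\O)cc2)O1`) gives 9290 nM and compound 3 (`COc1ccc(C2(c3ccccc3)CC(S(=O)(=O)c3ccc(F)cc3)=C(c3ccc(/C(N)=N\O)cc3)O2)cc1`) gives 11300 nM, so these two lie within the scatter of each other. Compound 2 (`CC1(Cc2ccccc2)CC(S(=O)(=O)c2c(F)cccc2F)=C(c2ccc(/C(N)=N\O)cc2)O1`) gives 27000 nM, which stands beyond the scatter from compound 1, on the side of lower toxicity. No two of these compounds differ in one place only, so the data hold no direct step to lean on.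

Compound 4 (`CC1(c2ccc(Cl)cc2)CC(S(=O)(=O)c2ccc(F)cc2)=C(c2ccc(/C(N)=N\O)cc2)O1`) keeps the core of compound 1 but carries chloro in place of 2-cyanophenyl on an aromatic carbon, para to a large group: chloro in place of 2-cyanophenyl on an aromatic carbon. With compound 1 at 9290 nM and compound 3 at 11300 nM as the closest guides, no change beyond the scatter is expected in this assay, only a possible slight move to a higher number. The estimated step of a 1.3-fold higher number from compound 1 to compound 4 (0.11 log units; within the scatter) stays within the scatter. Compound 4 is estimated at 12000 nM, with an expected range from 5000 nM to 28000 nM.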

Compound 4, half-maximal cytotoxic concentration: 31500 nM
For compound 4 the middle estimate is 2.6-fold (0.42 log units) below the measured one; measured number above the stated range.
By their numbers in this assay, from the lowest: compounds 1 and 3 (each within the scatter of the next); then compounds 2 and 4 (each within the scatter of the next).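

Chloro in place of 2-cyanophenyl, on an aromatic carbon para to a large group, gives the only direct step in this assay: a 3.4-fold higher number from compound 1 to compound 4 (0.53 log units; beyond the scatter), beyond the scatter and on the side of lower toxicity in this test. The earlier compounds shown here differed in more than one place and could not show that a single change at this position, with the rest of compound 1 kept, moves the number by more than the scatter. No measurement given here bears on why the number moves.

The change removes the nitrile and the aromatic ring that carries it and brings in chloro all at once, so the compounds shown do not separate these parts. Going by these compounds, how an amine or a carboxylic acid at this same place would read in this assay remains open.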